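The source may hold more compounds than are shown below. What is called first, only, known or untested is meant among the compounds shown, and "the series" means these compounds.

Compound 1, `O=C(CCCCCn1cc(Nc2ncc(Cl)c(Nc3cccc(Cl)c3)n2)cn1)NO`: 50 nM in a functional assay on Jurkat cells (Homo sapiens) for antiproliferative activity, read by MTT assay, with a stated time of 48 h; a higher number here means a weaker inhibitor, a lower number a stronger inhibitor.
Compound 2, `O=C(CCCCCn1cc(Nc2ncc(Cl)c(Nc3ccccc3Cl)n2)cn1)NO`: 310 nM in this assay.
Compound 3, `O=C(CCCCCCn1cc(Nc2ncc(Cl)c(Nc3ccc(F)cc3)n2)cn1)NO`: 120 nM in this assay.

Among these three, compound 3 stands second highest: compound 1 sits at a lower number, compound 2 at a higher number, both gaps beyond the scatter. Compound 4, `O=C(CCCCCCn1cc(Nc2ncc(Cl)c(Nc3ccc(Cl)cc3)n2)cn1)NO`, differs from compound 3 by one point: chloro in place of fluoro on an aromatic carbon. Among the measured compounds shown here, the only measured step, a 6.2-fold higher number from compound 1 to compound 2 (0.79 log units; beyond the scatter), concerns where the chloro sits on the ring, not the exchange of fluoro for chloro, so it gives no direct guide. With no comparable step shown, a change of about a halogen's size on the same aromatic carbon is expected to stay within the scatter, so the step of a 1.2-fold lower number from compound 3 to compound 4 (0.08 log units; within the scatter) is estimated to be small. Compound 4 is therefore expected to give about 100 nM, with a range of 50 nM to 200 nM.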

Compound 4, half-maximal inhibitory concentration: 100 nM
Beside the measured number, compound 4's estimate shows no gap at the digits printed; the measured number falls inside the stated range.
By their numbers in this assay, from the lowest: compounds 1, 4 and 3 (each within the scatter of the next, the first and the last beyond it); then compound 2.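

In this assay, chloro in place of fluoro on this aromatic carbon, para to a large group, gives a 1.2-fold lower number from compound 3 to compound 4 (0.08 log units; within the scatter) and so leaves the two halogens indistinguishable at this position. The earlier compounds shown here showed only a step on changing where chloro sits, with a 6.2-fold higher number from compound 1 to compound 2 (0.79 log units; beyond the scatter) for 2-chlorophenyl in place of 3-chlorophenyl, whereas this pair exchanges one halogen for another at a fixed place. Nothing given here explains the result.

On these data alone, how a methoxy, an amine or a carboxylic acid would read at this position remains open.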